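The source may report more compounds than this note shows. Statements on the series, on what has been measured and on what is new or still open speak of the compounds shown alone.

Measured in a physicochemical assay for solubility, measured as thermodynamic solubility, at pH 7.4; a higher number here means a more soluble compound, a lower number a less soluble compound:
- compound 1 `NC(=O)c1cc(Cl)c2c(Cl)c(C#CCCO)n([C@H]3CCCNC3)c2n1`: 144000 nM
- compound 2 `CC(O)C#Cc1c(Cl)c2c(Cl)cc(C(N)=O)nc2n1[C@H]1CCCNC1`: 206000 nM
- compound 3 `NC(=O)c1cc(Cl)c2c(Cl)c(C#CC3CCCO3)n([C@H]3CCCNC3)c2n1`: 207000 nM; 333000 nM (2 entries)

The nearest comparison on the numbers is a 1.4-fold higher number from compound 1 to compound 2 (0.16 log units; within the scatter), so those two values cannot be ordered. The entries for compound 3 are the several entries of compound 3 in this assay, 207000 nM; 333000 nM (2 entries).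

Compound 4 `COC(C)(C)CC#Cc1c(Cl)c2c(Cl)cc(C(N)=O)nc2n1[C@H]1CCCNC1` is unmeasured. Its difference is 1-methoxy-1-methylethyl in place of hydroxymethyl on a saturated chain carbon bound to a triple-bonded carbon. Within the data shown here, the one measured step that bears on this chain, a 1.4-fold higher number from compound 1 to compound 2 (0.16 log units; within the scatter), gives no direction. No change beyond the scatter is therefore expected in this assay, and the expected step is a 1.0-fold higher number from compound 1 to compound 4 (0.02 log units; within the scatter). For compound 4 the estimated value is 150000 nM, with an expected range of 60000 nM to 320000 nM.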

Compound 4, solubility: 1200 nM
Compound 4: the middle estimate sits 130-fold (2.10 log units) above what was measured; the measured number lies below the stated range.
By their numbers in this assay, from the lowest: compound 4; then compounds 1 and 2 (each within the scatter of the next).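

Among these compounds, on a saturated chain carbon bound to a triple-bonded carbon, the earlier compounds gave only a 1.4-fold higher number from compound 1 to compound 2 (0.16 log units; within the scatter) in this assay and left the chain looking indifferent. Replacing hydroxymethyl with 1-methoxy-1-methylethyl changes that picture, giving a 120-fold lower number from compound 1 to compound 4 (2.08 log units; beyond the scatter) and, against the 1-hydroxyethyl chain, a 170-fold lower number from compound 2 to compound 4 (2.23 log units; beyond the scatter). Both steps far exceed the spread between repeat entries of a single compound: the several entries of compound 3 in this assay, 207000 nM; 333000 nM (2 entries)

This single change removes the hydroxyl, adds branching and lengthens the group together, and the compounds shown do not separate these. On these data alone, how a tertiary alcohol, an unbranched methoxy chain or an amine at this place would read remains open.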